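The source may report more compounds than this note shows. Statements on the series, on what has been measured and on what is new or still open speak of the compounds shown alone.

Measured compounds in a functional assay on CHO cells for agonist activity at Alpha-1A adrenergic receptor (Homo sapiens), read by FLIPR and calcium flux; a higher number here means that more compound is needed for the effect, a lower number that less compound is needed:
compound 1 `Cc1n[nH]cc1-c1cccc2c1CCC2c1ncc[nH]1` gives 3 nM
compound 2 `c1cc(-c2ccn[nH]2)c2c(c1)C(c1ncc[nH]1)CC2` gives 52 nM
compound 3 `c1ccc2c(c1)CCC2c1ncc[nH]1` gives 473 nM

Compound 3 is the unsubstituted parent of the set and stands with the highest number of the three in this assay; compound 2 is nearest, and compound 1 is furthest from it.

The next compound, compound 4 `Cn1cc(-c2cccc3c2CCC3c2ncc[nH]2)cn1`, is the parent with one change: 1-methyl-1H-pyrazol-4-yl in place of hydrogen on an aromatic carbon.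

Going by the values given here, two measured steps bear on this change, both removing a pyrazolyl ring from the same aromatic carbon: a 160-fold higher number from compound 1 to compound 3 (2.20 log units; beyond the scatter), and a 9.1-fold higher number from compound 2 to compound 3 (0.96 log units; beyond the scatter). Read in reverse, adding a pyrazolyl at this carbon lowered the number in this assay in both cases, strongly for the 3-methyl-1H-pyrazol-4-yl group of compound 1 and modestly for the 1H-pyrazol-5-yl group of compound 2. Among the compounds with values here, the group entering in compound 4 is attached through the same ring position as in compound 1, with the methyl moved to a ring nitrogen; with only two examples, the size of the gain cannot be placed precisely, so an expected step of a 47-fold lower number from compound 3 to compound 4 (1.67 log units; beyond the scatter) is placed between the two measured ones, nearer compound 1.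

Compound 4 is therefore estimated at 10 nM in this assay, with a range from 2 nM to 60 nM.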

Compound 4, half-maximal effective concentration: > 2900 nM
Compound 4 gave a limit, no number; the forecaster's own chance of this, stated with the estimate: 2%; middle value at least 290-fold (2.46 log units) away from the limit.
By their numbers in this assay, from the lowest: compound 1; then compound 2; then compound 3. At a limit, above all of these: compound 4.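

Compound 4 stands only as a limit in this assay, not as a number: the limit of > 2900 nM in this assay, at which 1 of the 4 values shown sits.

A pyrazolyl ring on this aromatic carbon therefore does not lower the number by its presence alone: 1-methyl-1H-pyrazol-4-yl moves it the opposite way from the groups of compound 1 and compound 2, with an at least 6.1-fold higher number from compound 3 to compound 4 (0.78 log units; beyond the scatter). The choice of pyrazolyl group decides the outcome at this position, as shown by an at least 960-fold higher number from compound 1 to compound 4 (2.98 log units; beyond the scatter) and by an at least 55-fold higher number from compound 2 to compound 4 (1.74 log units; beyond the scatter), the first of these being a change in the place of the methyl on a ring with the same point of attachment.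

Compound 1 and compound 2 both keep a hydrogen on a ring nitrogen while the group of compound 4 has 0 hydrogen-bond donors, so the compounds shown cannot separate the presence of the methyl on nitrogen from the loss of that hydrogen. From the compounds shown here alone, an unmethylated 1H-pyrazol-4-yl would bear on that question, and how a ring other than a pyrazole, such as a phenyl or a pyridine, or a simple amine or carboxylic acid would behave on this carbon remains open.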